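Replacing the ring-bearing group with an open chain

The compounds below may be only part of what the source reports. "The series", "measured", "known", "first", "only" and "open" are said of these compounds alone.

In an ADME assay on A549 cells (Homo sapiens) for cytotoxicity, read by resazurin assay, with a stated time of 48 h (a lower number here means that less compound is tolerated, a higher number that more compound is tolerated), compound 1 `O=C(Nc1ccc(NCc2ccccc2)cc1Cl)c1cc(Cl)ccc1O` gives 19700 nM, and compound 2 `O=C(Nc1ccc(NCc2ccc(O)nc2)cc1Cl)c1cc(Cl)ccc1O` gives 98500 nM, the higher of the two numbers. Compound 3 `CC(CCO)Nc1ccc(NC(=O)c2cc(Cl)ccc2O)c(Cl)c1` carries 3-hydroxy-1-methylpropyl in place of (6-hydroxypyridin-3-yl)methyl on a nitrogen on an aromatic ring. For the measured compounds named here, the only measured step, a 5.0-fold higher number from compound 1 to compound 2 (0.70 log units; beyond the scatter), changed the ring within this same group, so it bears on the new change only loosely, as neither compound has an open chain there. In this assay a modest fall of similar or smaller size is expected, a 2.2-fold lower number from compound 2 to compound 3 (0.34 log units; beyond the scatter). Compound 3 is estimated at 45000 nM, with an expected range of 15000 nM to 110000 nM.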

Compound 3, half-maximal cytotoxic concentration: 200000 nM
The estimate for compound 3 lay 4.4-fold (0.65 log units) below the measured number, outside the stated range (above it).
By their numbers in this assay, from the lowest: compound 1; then compound 2; then compound 3.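

In this assay, the open chain carries the number higher than either ring-bearing group: 3-hydroxy-1-methylpropyl gives a 2.0-fold higher number from compound 2 to compound 3 (0.31 log units; beyond the scatter) against (6-hydroxypyridin-3-yl)methyl, and a 10-fold higher number from compound 1 to compound 3 (1.01 log units; beyond the scatter) against benzyl. This position on the nitrogen therefore does not need an aromatic ring for more compound to be tolerated, and compound 3 stands highest of the three. Nothing at hand accounts for the rise. On these data alone, it remains open whether the hydroxyl or the methyl branch of the chain contributes to this number. As far as these compounds go, how an unbranched 3-hydroxypropyl, or a chain ending in an amine or a carboxylic acid, would read at this nitrogen also remains open.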